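A few compounds are considered here, and "the series" means these few. Any claim that something is new, unique, unknown or untested is made for them only; others in the source may bear on it.

Measured in an ADME assay on RAW264.7 cells (Mus musculus) for cytotoxicity; a lower number here means a stronger inhibitor, a higher number a weaker inhibitor:
- Compound 1 `CCCc1nn(C)c2c(Nc3ccc(C(=O)O)cc3)nc(-c3cc(OC)c(OC)c(OC)c3)nc12`: > 50000 nM, a limit
- Compound 2 `CCCc1nn(C)c2c(NCC(C)C)nc(/C=C/c3ccccc3)nc12`: > 50000 nM, a limit
- Compound 3 `CCCc1nn(C)c2c(N3CCCC3)nc(-c3cc(OC)c(OC)c(OC)c3)nc12`: > 50000 nM, a limit

Compound 2 offers no exact number to start from, only its limit of > 50000 nM. The same holds across the set: the limit of > 50000 nM in this assay, at which 3 of the 3 values shown sit.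

Compound 4 `CCCc1nn(C)c2c(Nc3ccccc3)nc(/C=C/c3ccccc3)nc12` has not yet been measured. It carries phenyl in place of isobutyl on a nitrogen on an aromatic ring.

Among the compounds with values here, the only measured step is a step that the two limits leave unreadable from compound 1 to compound 3, so it gives no size to work from. No step beyond the scatter is therefore expected in this assay. The expected change is an at least 1.1-fold lower number from compound 2 to compound 4 (0.04 log units; that floor lies within the scatter). For compound 4 the estimated value is 45000 nM, with an expected range of 15000 nM to 100000 nM.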

Compound 4, half-maximal inhibitory concentration: > 50000 nM
Compound 4: only a limit was reported; the forecaster's own chance of this, stated with the estimate: 65%; middle value at least 1.1-fold (0.04 log units) away from the limit.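

No step can be read from compound 2 to compound 4, because both values are limits and not exact numbers: the limit of > 50000 nM in this assay, at which 4 of the 4 values shown sit.

Going by these compounds, whether phenyl in place of isobutyl changes the result in this assay at all, and by how much, stays open.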